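The source may report more compounds than this note shows. Statements on the series, on what has been measured and on what is new or still open speak of the compounds shown alone.

Three compounds from this set share one core and differ only in the aromatic group carried on the saturated chain carbon bound to a nitrogen on an aromatic ring. Compound 1 is `OC[C@H]1O[C@@H](n2cnc3c(NCc4cccc(Br)c4)ncnc32)[C@H](O)[C@@H]1O` and compound 2 is `COc1ccccc1CNc1ncnc2c1ncn2[C@@H]1O[C@H](CO)[C@@H](O)[C@H]1O`. In an ADME assay on NIH3T3 cells (Mus musculus) for cytotoxicity, with a stated time of 72 h (on this read-out higher numbers stand for weaker inhibition and lower numbers for stronger inhibition), compound 1 gives only a limit, > 166000 nM, and not a number; this is the limit of > 166000 nM in this assay, at which 1 of the 3 values shown sits. In this assay compound 2 gives 140000 nM. Among the measured compounds shown here, the one measured step, an at least 1.1-fold lower number from compound 1 to compound 2 (0.07 log units; that floor lies within the scatter), therefore shows no change beyond the scatter. Compound 3 is `OC[C@H]1O[C@@H](n2cnc3c(NCc4ccc(Cl)c(Cl)c4)ncnc32)[C@H](O)[C@@H]1O`; in this assay compound 3 gives "not determined" (no result reported), so it stands nowhere on the numbers shown. Compound 4 is `COc1cccc(CNc2ncnc3c2ncn3[C@@H]2O[C@H](CO)[C@@H](O)[C@H]2O)c1O`. It differs from compound 3 by 2-hydroxy-3-methoxyphenyl in place of 3,4-dichlorophenyl on a saturated chain carbon bound to a nitrogen on an aromatic ring. For the measured compounds named here, no measured step covers this change, and the two measured compounds both sit at the weak end of the scale, so compound 4 is expected to behave much as compound 1 and compound 2 do, with a number that may again reach a limit. Compound 4 is estimated to give 150000 nM in this assay, within a range from 60000 nM to 400000 nM.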

Compound 4, half-maximal inhibitory concentration: > 166000 nM
Compound 4 was reported as a limit; the forecaster's own chance of this, stated with the estimate: 50%; at least 1.1-fold (0.04 log units) between middle value and limit.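

Among the compounds shown here, compound 4 gives a limit and not a number in this assay, so a group carrying both a hydroxy and a methoxy substituent, 2-hydroxy-3-methoxyphenyl, also reaches the limit on a saturated chain carbon bound to a nitrogen on an aromatic ring: the limit of > 166000 nM in this assay, at which 2 of the 4 values shown sit. The one readable step is an at least 1.1-fold higher number from compound 2 to compound 4 (0.07 log units; that floor lies within the scatter), so this change shows no shift beyond the scatter. The step linking compound 1 and compound 4 cannot be read, as each end is a limit.

The compounds shown leave open whether an aromatic group carrying an amine or a carboxylic acid would give a clearly lower number in this assay. They also leave open what a longer chain between the ring nitrogen and the aromatic group would do.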